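Azole for phenyl on the ketal side chain of compound 1

The source may report more compounds than this note shows. Statements on the series, on what has been measured and on what is new or still open speak of the compounds shown alone.

Measured so far:
- compound 1 `CCC(C)n1ncn(-c2ccc(N3CCN(c4ccc(OC[C@@H]5CO[C@@](Cc6ccccc6)(c6ccc(Cl)cc6Cl)O5)cc4)CC3)cc2)c1=O`: 513 nM
- compound 2 `CCC(C)n1ncn(-c2ccc(N3CCN(c4ccc(OC[C@@H]5CO[C@@](Cn6cnc(C)n6)(c6ccc(Cl)cc6Cl)O5)cc4)CC3)cc2)c1=O`: 272 nM

Both numbers come from a functional assay on HUVEC cells (Homo sapiens), read by scintillation counting and thymidine incorporation, with a stated time of 24 h; on this read-out lower numbers stand for stronger inhibition and higher numbers for weaker inhibition. Compound 1 gives 513 nM and stands with the highest number of the two; its nearest neighbour is compound 2, which gives 272 nM. Among the measured compounds shown here, the only measured step, a 1.9-fold lower number from compound 1 to compound 2 (0.28 log units; within the scatter), exchanges the phenyl on a saturated chain carbon bound to a saturated ring carbon for 3-methyl-1H-1,2,4-triazol-1-yl, and it stays within the scatter.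

Compound 3 `CCc1nccn1C[C@@]1(c2ccc(Cl)cc2Cl)OC[C@@H](COc2ccc(N3CCN(c4ccc(-n5cnn(C(C)CC)c5=O)cc4)CC3)cc2)O1` has not yet been measured in this assay. It differs from compound 1 at the same place:

2-ethyl-1H-imidazol-1-yl in place of phenyl on a saturated chain carbon bound to a saturated ring carbon

The step from compound 1 to compound 2 bears directly on this change, since a five-membered aromatic ring with hetero atoms again replaces the phenyl at the same position, and that step was small. One comparable step is a thin basis, so the expectation is cautious: the number for compound 3 is expected to sit near those of compound 1 and compound 2, with a step of about a 1.6-fold lower number from compound 1 to compound 3 (0.20 log units; within the scatter) and no move beyond the scatter claimed. Compound 3 is therefore estimated at 320 nM, in a range from 120 nM to 850 nM.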

Compound 3, half-maximal inhibitory concentration: 224 nM
Compound 3: middle estimate off by 1.4-fold (0.15 log units), on the high side; low and high end bracket the measured number.
By their numbers in this assay, from the lowest: compounds 3, 2 and 1 (each within the scatter of the next, the first and the last beyond it).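

In this assay, among the compounds shown here, 2-ethyl-1H-imidazol-1-yl in place of phenyl gives a 2.3-fold lower number from compound 1 to compound 3 (0.36 log units; beyond the scatter) and is the first change on this saturated chain carbon bound to a saturated ring carbon to move the number beyond the scatter, though only modestly. This does not make a general rule that a ring with nitrogen atoms outperforms phenyl here: compound 2 goes against it, with a 1.9-fold lower number from compound 1 to compound 2 (0.28 log units; within the scatter) still inside the scatter. Exchanging one nitrogen-containing ring for the other gives a 1.2-fold lower number from compound 2 to compound 3 (0.08 log units; within the scatter), so the data do not separate 2-ethyl-1H-imidazol-1-yl from 3-methyl-1H-1,2,4-triazol-1-yl, and only the comparison with phenyl reaches beyond the scatter.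

No measurement available here explains the size of any of these steps. Still open, as far as these compounds go, is what the ethyl group contributes, which plain 1H-imidazol-1-yl at the same place would test, and whether an aromatic ring is needed at all on this chain carbon, which an open-chain amine or a carboxylic acid there would test.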